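A few compounds are considered here, and "the series" means these few. Any claim that something is new, unique, unknown or untested is made for them only; others in the source may bear on it.

Measured in an assay on isolated protein for inhibition of DNA topoisomerase 1 (Homo sapiens), with a stated time of 30 min, tested at 100 uM; on this read-out lower numbers stand for a weaker effect and higher numbers for a stronger effect at the one concentration tested:
compound 1 `Oc1ccc(-c2cc(-c3ccccn3)nc(-c3ccccc3Cl)c2)cc1` gives 5.2%
compound 2 `Oc1cccc(-c2cc(-c3ccccc3)nc(-c3ccc(Cl)cc3)c2)c1` gives 7.1%
compound 3 `Oc1cccc(-c2cc(-c3ccccn3)nc(-c3ccccc3Cl)c2)c1` gives 0%

All three numbers in this assay lie within the usual scatter of one another, so none of the compounds can be ranked against the others. The change from compound 3 to compound 1 is 4-hydroxyphenyl in place of 3-hydroxyphenyl on an aromatic carbon and gave a step of a number 5.2 percentage points higher from compound 3 to compound 1 (within the scatter). Compound 4 `Oc1ccc(-c2cc(-c3ccccc3)nc(-c3ccc(Cl)cc3)c2)cc1` has not yet been measured. It arises from compound 2 by the same kind of change, (4-hydroxyphenyl in place of 3-hydroxyphenyl on an aromatic carbon); the surroundings differ, since in compound 2 the place is meta to a 4-chlorophenyl group and meta to a phenyl group, whereas in compound 3 it is meta to a 2-chlorophenyl group and meta to a pyridin-2-yl group. How the cores of compound 2 and compound 3 differ is not broken down here. For compound 4 a step of a number 1.9 percentage points higher from compound 2 to compound 4 (within the scatter) is expected, resting on the small step of a number 5.2 percentage points higher from compound 3 to compound 1 (within the scatter). Compound 4 is therefore estimated at 9%, expected between 0% and 22%.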

Compound 4, a percentage reported as inhibition, at one concentration (the size of the read-out at that concentration, not a potency): 68%
The estimate for compound 4 lay 59 percentage points below the measured number; the whole stated range lies below it.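

In this assay, putting 4-hydroxyphenyl in place of 3-hydroxyphenyl opposite the ring nitrogen gave a number 60.9 percentage points higher from compound 2 to compound 4 (beyond the scatter). The size of this change did not carry from one core to the other: the same change on two cores in this assay, a number 5.2 percentage points higher (within the scatter) from compound 3 to compound 1 and a number 60.9 percentage points higher (beyond the scatter) from compound 2 to compound 4, 55.7 percentage points apart, beyond the scatter of two such steps. This shows that the step depends on the core that carries it, but not which core difference matters, as the cores differ both in a phenyl against a pyridin-2-yl group and in a 4-chlorophenyl against a 2-chlorophenyl group.

The compounds shown leave open whether either of those two differences alone would change the step. They also leave open what a methoxy group, an amine or a carboxylic acid in place of the hydroxyl would give on the core of compound 4.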